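A few compounds are considered here, and "the series" means these few. Any claim that something is new, unique, unknown or untested is made for them only; others in the source may bear on it.

Measured so far in a physicochemical assay for solubility, read by HPLC, in phosphate buffer, measured as kinetic solubility, at pH 7.4 (a higher number here means a more soluble compound, a lower number a less soluble compound), for three compounds:
- compound 1 `CC(=O)c1cc(-c2ccc(S(N)(=O)=O)cc2)n(-c2ccc(Cl)cc2)n1` gives 86800 nM
- compound 2 `CC(C)(C)C(=O)c1cc(-c2ccc(S(N)(=O)=O)cc2)n(-c2ccc(Cl)cc2)n1` gives 6600 nM
- compound 3 `NS(=O)(=O)c1ccc(-c2cc(C(=O)C3CC3)nn2-c2ccc(Cl)cc2)cc1` gives 25600 nM

Compound 3 holds the second highest of these three numbers, with compound 1 above it and compound 2 below it. The next compound is compound 4 `NS(=O)(=O)c1ccc(-c2cc(C(=O)C3CCCC3)nn2-c2ccc(Cl)cc2)cc1` which carries cyclopentyl in place of cyclopropyl on a carbonyl carbon.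

All three measured steps sit at this same carbonyl carbon. Both replacements of methyl lowered the number: tert-butyl gave a large step (a 13-fold lower number from compound 1 to compound 2 (1.12 log units; beyond the scatter)) and cyclopropyl a modest one (a 3.4-fold lower number from compound 1 to compound 3 (0.53 log units; beyond the scatter)). The remaining step (a 3.9-fold higher number from compound 2 to compound 3 (0.59 log units; beyond the scatter)) is also modest and places cyclopropyl between the other two groups. Within these three compounds the number falls from methyl through cyclopropyl to tert-butyl, and none goes against that order, but three compounds make a thin basis and no cyclopentyl compound has been measured.

A modest downward step beyond the scatter is therefore expected in this assay, taking the number towards that of compound 2 (6600 nM). The expected change is a 3.0-fold lower number from compound 3 to compound 4 (0.48 log units; beyond the scatter) in this estimate. For compound 4 the estimated value is 8500 nM (expected range 2800 nM to 22000 nM).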

Compound 4, solubility: 4600 nM
Beside the measured number, compound 4's estimate is 1.8-fold (0.27 log units) above it; measured number inside the range.
By their numbers in this assay, from the lowest: compounds 4 and 2 (each within the scatter of the next); then compound 3; then compound 1.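

In this assay, going from the three-membered to the five-membered ring on a carbonyl carbon gives a 5.6-fold lower number from compound 3 to compound 4 (0.75 log units; beyond the scatter), so the step from cyclopropyl to cyclopentyl is beyond the scatter, while a 1.4-fold lower number from compound 2 to compound 4 (0.16 log units; within the scatter) leaves cyclopentyl and tert-butyl unseparated. Against methyl, the change gives a 19-fold lower number from compound 1 to compound 4 (1.28 log units; beyond the scatter), a large step of the same class as a 13-fold lower number from compound 1 to compound 2 (1.12 log units; beyond the scatter), so two differently shaped carbon groups now sit together at the low end, with cyclopropyl apart from them and methyl at the top, and none of the four compounds goes against this order. Nothing available here speaks to why the number follows the group at this position.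

Still open, from the compounds shown here alone, is whether the order holds for other carbon groups on the carbonyl carbon, such as cyclobutyl, cyclohexyl or a longer chain like n-butyl, or whether the low end is simply a floor shared by all of them. Also open is how a group carrying an amine or a carboxylic acid at this place would compare, since every group shown so far is carbon only.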